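Methyl on the Phenyl Ring of Compound 3

The source may report more compounds than this note shows. Statements on the series, on what has been measured and on what is new or still open speak of the compounds shown alone.

Compound 3 `Cc1[nH]c2ccccc2c1C1=C(Cl)C(=O)C(c2c(-c3ccccc3)[nH]c3ccccc23)=C(Cl)C1=O` gives 2.29 ug/mL in a functional assay on MCF7 cells (Homo sapiens) for antiproliferative activity, read by CCK-8 assay, with a stated time of 48 h; on this read-out higher numbers stand for weaker inhibition and lower numbers for stronger inhibition. Compound 2 `Cc1ccc(-c2[nH]c3ccccc3c2C2=C(Br)C(=O)C(c3c(C)[nH]c4ccccc34)=C(Br)C2=O)cc1` gives 3.25 ug/mL in this assay, and the two numbers sit within the scatter of each other. Compound 1 `Cc1ccc(-c2[nH]c3ccccc3c2C2=C(Br)C(=O)C(Br)=C(Br)C2=O)cc1` gives only a limit, > 25 ug/mL, in this assay. Within the data shown here, the one step available, an at least 7.6-fold lower number from compound 1 to compound 2 (0.88 log units; beyond the scatter), concerns 2-methyl-1H-indol-3-yl in place of bromo on a double-bonded ring carbon and does not touch the change considered here.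

Compound 4 `Cc1ccc(-c2[nH]c3ccccc3c2C2=C(Cl)C(=O)C(c3c(C)[nH]c4ccccc34)=C(Cl)C2=O)cc1` differs from compound 3 by methyl in place of hydrogen on an aromatic carbon of a six-membered aromatic ring of carbon only, para to a large group; cut one bond further out, phenyl becomes 4-methylphenyl. Among the measured compounds shown here, no measured step tests such a change, so no shift beyond the scatter is expected in this assay. Compound 4 is therefore expected to give about 2.3 ug/mL, with a range from 1 ug/mL to 5.5 ug/mL. The expected step of a 1.0-fold higher number from compound 3 to compound 4 (0.00 log units; within the scatter) is thus within the scatter.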

Compound 4, half-maximal inhibitory concentration: 2.8 ug/mL
The estimate for compound 4 lay 1.2-fold (0.09 log units) below the measured number, within the range that was stated.
By their numbers in this assay, from the lowest: compounds 3, 4 and 2 (each within the scatter of the next). At a limit, above all of these: compound 1.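

In this assay, methyl in place of hydrogen on the phenyl ring gives a 1.2-fold higher number from compound 3 to compound 4 (0.09 log units; within the scatter), so phenyl and 4-methylphenyl cannot be told apart on this read-out. Among these compounds, this is the first direct reading of this position, as the only earlier step concerned the replacement of bromo on a double-bonded ring carbon and left the phenyl ring unchanged. No measurement shown bears on why this change gives such a result.

The compounds shown leave open whether a different group at this place on the phenyl ring, such as an amine, a carboxylic acid or a longer chain, would move the number beyond the scatter. On these data alone, whether the same methyl change reads alike on a core carrying bromo in place of chloro also remains open.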